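Removing the Hydroxy Group from a Weak Inhibitor

The source may hold more compounds than are shown below. What is called first, only, known or untested is meant among the compounds shown, and "the series" means these compounds.

Compound 1 `NC(=O)[C@H](CO)NCc1ccc(OCc2cccc(F)c2)cc1`: 100000 nM
Compound 2 `NC(=O)[C@H](CO)NCc1ccc(OCc2ccccc2)cc1`: 90000 nM

In an assay on mitochondria for inhibition of Amine oxidase [flavin-containing] A (Rattus norvegicus) (on this read-out lower numbers stand for stronger inhibition and higher numbers for weaker inhibition), compound 2 gives 90000 nM, the lowest of the two numbers, while compound 1 gives 100000 nM; the step of a 1.1-fold lower number from compound 1 to compound 2 (0.05 log units; within the scatter) stays within the scatter. Compound 3 `C[C@H](NCc1ccc(OCc2ccccc2)cc1)C(N)=O` carries hydrogen in place of hydroxy on a saturated chain carbon, two bonds along the chain from an amine nitrogen and a carbonyl carbon. Going by the values given here, the only measured step concerns the fluoro group on the ring and does not touch this part of the molecule, so nothing measured bears on the change. Without a guide, compound 3 is expected near its parent, estimated at 90000 nM with a range of 30000 nM to 300000 nM. The expected step is no change at the digits printed from compound 2 to compound 3 (within the scatter), none beyond the scatter.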

Compound 3, half-maximal inhibitory concentration: 101000 nM
Estimate against measurement, compound 3: 1.1-fold (0.05 log units) below; measured number inside the range.
By their numbers in this assay, from the lowest: compounds 2, 1 and 3 (each within the scatter of the next).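

Going by these compounds alone, replacing hydroxymethyl with methyl gives a 1.1-fold higher number from compound 2 to compound 3 (0.05 log units; within the scatter) in this assay, so this is the first look at this position, and the hydroxy group shows no effect on the number beyond the scatter. Compound 3 therefore stays as weak an inhibitor as compound 2, even without that oxygen. No available evidence explains this result.

Going by these compounds, whether a larger replacement here, such as an amine, a carboxylic acid or a longer chain, would alter inhibition remains open. So does whether any change at this position can strengthen it.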